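The compounds below may be only part of what the source reports. "The series", "measured", "known", "first", "only" and "open" are said of these compounds alone.

In an ADME assay on L929 cells (Mus musculus) for cytotoxicity, with a stated time of 72 h (a higher number here means a weaker inhibitor, a lower number a stronger inhibitor), compound 1, `CCOC(=O)COc1ccc2c(c1)B(O)OC2`, gives only a limit, > 10 ug/mL. Compound 2, `COC(=O)COc1ccc2c(c1)B(O)OC2`, likewise gives a limit in this assay, > 10 ug/mL. The change between them is hydrogen in place of methyl on a saturated chain carbon bound to an oxygen next to a carbonyl group, and in this assay it makes a step that the two limits leave unreadable from compound 1 to compound 2. Compound 3, `CCC(=O)C(C)Oc1ccc2c(c1)B(O)OC2`, also stops at a limit, > 10 ug/mL; how its core differs from that of compound 1 is not broken down here. Compound 4, `CC(=O)C(C)Oc1ccc2c(c1)B(O)OC2`, is still to be measured. Its difference from compound 3 is hydrogen in place of methyl on a saturated chain carbon bound to a carbonyl carbon: the same kind of change as from compound 1 to compound 2, though there the place was a saturated chain carbon bound to an oxygen next to a carbonyl group, here one bound to a carbonyl carbon. Since (the limit of > 10 ug/mL in this assay, at which 3 of the 3 values shown sit), compound 4 is expected to give a step that the limit leaves unreadable from compound 3 to compound 4 in this assay. The estimate for compound 4 is therefore 15 ug/mL, between 10 ug/mL and 40 ug/mL.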

Compound 4, half-maximal inhibitory concentration: > 10 ug/mL
Compound 4: only a limit was reported; the forecaster's own chance of this, stated with the estimate: 85%; the middle value lies beyond the limit too.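

In this assay, within the data shown here, compound 2, compound 3 and compound 4 all stop at a limit, so no step to compound 4 can be read. The compounds shown leave open how any of these changes affects cytotoxicity, because every value is only a limit: the limit of > 10 ug/mL in this assay, at which 4 of the 4 values shown sit.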